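This account rests on a few compounds, and the source may have more. Where it says the series, first, only, none or still open, it means among the compounds named here.

Three ureas built on one shared core have been tested for how much compound it takes to harm human kidney-derived cells, in an ADME assay on HEK293 cells (Homo sapiens) for cytotoxicity, with a stated time of 72 h; on this read-out higher numbers stand for an effect only at larger amounts of compound and lower numbers for an effect already at smaller amounts. Compound 1 `CSc1ccccc1NC(=O)Nc1cc(C)nc2ccccc12` reaches only the limit of that test, giving > 25000 nM. Compound 3 `Cc1cc(NC(=O)Nc2ccc3[nH]cnc3c2)c2ccccc2n1` likewise stops at a limit, with > 25000 nM. For the measured compounds named here, compound 2 `COC(=O)c1ccc(NC(=O)Nc2cc(C)nc3ccccc23)cc1` is the one member with an actual number, at 15000 nM. Compound 1 thus stands among the values that sit at the edge of what the test can report, as the limit of > 25000 nM in this assay, at which 2 of the 3 values shown sit, describes, with no number of its own.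

Compound 4 `Cc1cc(NC(=O)Nc2ccccc2C(N)=O)c2ccccc2n1` has not yet been measured. It differs from compound 1 in a single place: carbamoyl in place of methylsulfanyl on an aromatic carbon. Since the values of compound 1 and compound 3 both rest at the limit of > 25000 nM in this assay, at which 2 of the 3 values shown sit, and compound 2 is not far from it, little room exists for a visible move. In this assay the expected step is a number no higher from compound 1 to compound 4 (the limit leaves the size open), that is, none beyond the scatter. Compound 4 is therefore expected to give 25000 nM, with a range from 12000 nM to 50000 nM, and it may well again return only a limit.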

Compound 4, half-maximal effective concentration: > 25000 nM
Compound 4 ended at the assay's limit; the forecaster's own chance of this, stated with the estimate: 70%; the middle value lies on the limit itself.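

Compound 1 and compound 4 each stop at a limit of the test, so no step between them can be read in this assay: the limit of > 25000 nM in this assay, at which 3 of the 4 values shown sit.

The compounds shown leave open whether carbamoyl in place of methylsulfanyl changes the amount needed to harm these cells.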